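Phenyl in Place of Thiophen-3-yl on a Weak Nucleoside

This account rests on a few compounds, and the source may have more. Where it says the series, first, only, none or still open, it means among the compounds named here.

Compound 1 `Nc1nc(N)c2c(-c3ccsc3)cn([C@@H]3O[C@H](CO)[C@@H](O)[C@H]3O)c2n1` gives > 20000 nM in a functional assay on HCT-116 cells (Homo sapiens), read by MTT assay, with a stated time of 72 h (a lower number here means a stronger inhibitor, a higher number a weaker inhibitor), which is a limit of the assay.
Compound 2 `C#Cc1cn([C@@H]2O[C@H](CO)[C@@H](O)[C@H]2O)c2ncnc(OC)c12` gives 4060 nM in this assay.
Compound 3 `Cc1nc(N)c2c(-c3ccsc3)cn([C@@H]3O[C@H](CO)[C@@H](O)[C@H]3O)c2n1` gives > 20000 nM in this assay, which is a limit of the assay.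

Compound 1 thus stands at the limit of > 20000 nM in this assay, at which 2 of the 3 values shown sit, so only a limit is known for it. The step that the two limits leave unreadable from compound 1 to compound 3 cannot be read, as both of its ends are limits. Compound 4 `Nc1nc(N)c2c(-c3ccccc3)cn([C@@H]3O[C@H](CO)[C@@H](O)[C@H]3O)c2n1` differs from compound 1 by phenyl in place of thiophen-3-yl on an aromatic carbon. Within the data shown here, no measured step involves this change, and compound 2 has a different core, so it gives no guide. Compound 4 is therefore expected to remain weak, near 25000 nM, in a range from 8000 nM to 80000 nM. The step this estimate means, a step that the limit leaves unreadable from compound 1 to compound 4, is expected to be small, with a limit again likely.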

Compound 4, half-maximal inhibitory concentration: > 20000 nM
Compound 4: no number, only a limit (the forecaster's own chance of this, stated with the estimate: 70%); the middle value is on the limit's open side.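

Among these compounds, compound 4, like compound 1, gives only a limit in this assay, so no step between them can be read. Going by these compounds, whether phenyl and thiophen-3-yl differ in strength on this core remains open.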